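This account rests on a few compounds, and the source may have more. Where it says the series, first, only, none or still open, it means among the compounds named here.

Measured compounds in a functional assay on HCT-15 cells (Homo sapiens) for antiproliferative activity, read by MTT assay, with a stated time of 72 h; a lower number here means a stronger inhibitor, a higher number a weaker inhibitor:
- compound 1, `COc1ccc(-n2ccnc2-c2cc(OC)c(OC)c(OC)c2)cc1[N+](=O)[O-]`: 1000 nM
- compound 2, `COc1ccc(-n2ccnc2-c2cc(OC)c(OC)c(OC)c2)cc1N`: 100 nM
- compound 3, `COc1ccc(NC(=O)c2cc(OC)c(OC)c(OC)c2)cc1[N+](=O)[O-]`: 17600 nM

Compounds 1 and 2 share one core and differ in a single place. The change from compound 1 to compound 2 is amino in place of nitro on an aromatic carbon and it gives a 10-fold lower number from compound 1 to compound 2 (1.00 log units; beyond the scatter) in this assay. Compound 3 carries a different core; how the core of compound 3 differs from the core of compound 1 is not broken down here. In this assay compound 3 gives 17600 nM, the highest of the three numbers, and the gaps to compound 1 and to compound 2 are both beyond the usual scatter.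

Compound 4, `COc1ccc(NC(=O)c2cc(OC)c(OC)c(OC)c2)cc1N`, has not yet been measured. It differs from compound 3 as amino in place of nitro on an aromatic carbon. The words describing the place of this change are the same as those for the change from compound 1 to compound 2, so this is the same change carried onto the core of compound 3.

Going by the values given here, the only guide to its size is the single earlier instance, a 10-fold lower number from compound 1 to compound 2 (1.00 log units; beyond the scatter), which rests on one pair of measurements on a different core. Among the compounds with values here, with that as the sole precedent, a step of similar direction and somewhat smaller size is expected from compound 3 to compound 4, namely a 7.0-fold lower number from compound 3 to compound 4 (0.85 log units; beyond the scatter) in this assay. For compound 4 the estimated value in this assay is 2500 nM, expected to lie between 800 nM and 8000 nM.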

Compound 4, half-maximal inhibitory concentration: 6500 nM
Compound 4: middle estimate off by 2.6-fold (0.41 log units), on the low side, and the stated range covers the measured number.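

In this assay, amino in place of nitro on an aromatic carbon again gives a lower number on the second core, with a 2.7-fold lower number from compound 3 to compound 4 (0.43 log units; beyond the scatter) as the new step, so the direction of the change carries over from the core of compound 1 to the core of compound 3. The size does not carry over intact, as setting the two steps side by side shows: the same change on two cores in this assay, a 10-fold lower number (1.00 log units; beyond the scatter) from compound 1 to compound 2 and a 2.7-fold lower number (0.43 log units; beyond the scatter) from compound 3 to compound 4, 3.7-fold (0.57 log units) apart, beyond the scatter of two such steps. Going by these compounds alone, each core contributes only a single pair of measurements, so the data do not show which feature of the two cores goes with the gap, how the change would behave on any further core, or whether the same holds outside this assay.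

The compounds shown leave open how a hydroxyl group, a methylamino group or an acetylamino group would read in place of the amino on either core. They also leave open whether an ethoxy group in place of the methoxy group, to which the changed position is ortho, would alter the size of the step on either core.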